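Swapping methoxymethyl for (4-nitrophenyl)carbonyl on a shared core

The source may hold more compounds than are shown below. What is called first, only, known or untested is meant among the compounds shown, and "the series" means these compounds.

Compound 1 `CC(=O)OC/C1=C/C[C@](C)(CCC=C(C)C)/C=C/[C@@H](OC(=O)C=C(C)C)[C@](C)(O)/C=C/C1=O`: 2950 nM
Compound 2 `COCOC/C1=C/C[C@](C)(CCC=C(C)C)/C=C/[C@@H](OC(=O)C=C(C)C)[C@](C)(O)/C=C/C1=O`: 3710 nM

In a functional assay on SW480 cells (Homo sapiens) for antiproliferative activity, read by MTT assay, with a stated time of 48 h (on this read-out higher numbers stand for weaker inhibition and lower numbers for stronger inhibition), compound 2 gives 3710 nM, and this value lies within the scatter of compound 1 at 2950 nM. Within the data shown here, only this pair has been measured, so compound 2 stands level with the one neighbour available. That single step, a 1.3-fold higher number from compound 1 to compound 2 (0.10 log units; within the scatter), exchanges acetyl for methoxymethyl on an oxygen on a saturated carbon.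

Compound 3 `CC(C)=CCC[C@]1(C)/C=C/[C@@H](OC(=O)C=C(C)C)[C@](C)(O)/C=C/C(=O)/C(COC(=O)c2ccc([N+](=O)[O-])cc2)=C\C1` has not yet been measured in this assay. It differs from compound 2 at that same kind of place: (4-nitrophenyl)carbonyl in place of methoxymethyl on an oxygen on a saturated carbon. In words, (4-nitrophenyl)carbonyl stands in place of methoxymethyl. Among the measured compounds shown here, no measured compound carries an aromatic ring in this group, so the evidence is thin and the range must stay wide. For the measured compounds named here, the only guide is the exchange at this place, a 1.3-fold higher number from compound 1 to compound 2 (0.10 log units; within the scatter), which stayed small. On that basis no change beyond the scatter is expected, and the expected step is a 1.2-fold lower number from compound 2 to compound 3 (0.09 log units; within the scatter). For compound 3 the estimated value is 3000 nM, with an expected range of 1200 nM to 7500 nM.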

Compound 3, half-maximal inhibitory concentration: 570 nM
Compound 3: the middle estimate sits 5.3-fold (0.72 log units) above what was measured, and the stated range ends above it.
By their numbers in this assay, from the lowest: compound 3; then compounds 1 and 2 (each within the scatter of the next).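

In this assay, this oxygen on a saturated carbon turns out not to be indifferent to the group it carries: the exchange of acetyl for methoxymethyl had stayed within the scatter, whereas (4-nitrophenyl)carbonyl in place of methoxymethyl gives a 6.5-fold lower number from compound 2 to compound 3 (0.81 log units; beyond the scatter). Read against the acetyl group, the same change is 4-nitrophenyl in place of methyl on a carbonyl carbon, and it gives a 5.2-fold lower number from compound 1 to compound 3 (0.71 log units; beyond the scatter), so the lower number holds against both measured neighbours and does not rest on a single comparison. No measurement shown here bears on why the number falls.

On these data alone, the three compounds cannot separate the contribution of the aromatic ring from that of the nitro group, so it remains open whether a plain benzoyl group, or a benzoyl group carrying an amine or a methoxy group in place of the nitro group, would keep the lower number. As far as these compounds go, it is equally open whether the carbonyl matters here, which a benzyl group on the same oxygen would test, and whether a longer chain without any ring would behave like acetyl.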